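This account rests on a few compounds, and the source may have more. Where it says the series, first, only, none or still open, it means among the compounds named here.

Working notes on the series. Three compounds carry a measured value: compound 1 `O=C(/C=C/c1ccc(B(O)O)cc1)c1ccc[nH]1`, compound 2 `O=C(/C=C/c1ccc(F)c(Cl)c1)c1ccc(B(O)O)cc1` and compound 3 `O=C(/C=C/c1ccc(I)cc1)c1ccc(O)cc1`. In a functional assay on MCF7 cells (Homo sapiens) for inhibition (on this read-out higher numbers stand for weaker inhibition and lower numbers for stronger inhibition), compound 1 gives 19000 nM. In this assay compound 2 gives 6000 nM, the lowest of the three numbers; compound 3 gives 7000 nM, which sits within the scatter of compound 2, while the number for compound 1 lies beyond the scatter of compound 2. Compound 4 `O=C(/C=C/c1ccc(F)c(F)c1)c1ccc(B(O)O)cc1` has not been measured. Compound 4 differs from compound 2 by fluoro in place of chloro on an aromatic carbon. Among the compounds with values here, no measured pair shows such a step here, so the expectation is a small change, possibly a slight loss, not clearly beyond the scatter; the step from compound 2 to compound 4 is estimated at a 1.3-fold higher number from compound 2 to compound 4 (0.12 log units; within the scatter). For compound 4 the expected value in this assay is 8000 nM, in the range 3000 nM to 20000 nM.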

Compound 4, half-maximal inhibitory concentration: 7800 nM
Compound 4: middle estimate off by 1.0-fold (0.01 log units), on the high side; measured number inside the range.
By their numbers in this assay, from the lowest: compounds 2, 3 and 4 (each within the scatter of the next); then compound 1.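

In this assay the series gains its first step that differs in one place: fluoro in place of chloro on this aromatic carbon, ortho to a fluoro group and meta to a large group, gives a 1.3-fold higher number from compound 2 to compound 4 (0.11 log units; within the scatter). At this position, the read-out therefore does not separate the two halogens. Nothing measured bears on the reason for this result. On these data alone, it remains open whether an amine or a methoxy group at this position would stay within the scatter of compound 2. A single step also leaves open whether the same swap would read alike at another position.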